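A few compounds are considered here, and "the series" means these few. Any claim that something is new, unique, unknown or untested is made for them only; others in the source may bear on it.

Three chalcone-type amides carrying a 2-bromoacryloyl group were tested in a functional assay on L1210 cells (Mus musculus) for antiproliferative activity, with a stated time of 48 h; on this read-out lower numbers stand for stronger inhibition and higher numbers for weaker inhibition. Compound 1 `C=C(Br)C(=O)Nc1ccc(/C=C/C(=O)c2ccc(OC)cc2)cc1` gives 980 nM, compound 2 `C=C(Br)C(=O)Nc1ccc(/C=C/C(=O)c2cccc(OC)c2)cc1` gives 2100 nM, and compound 3 `C=C(Br)C(=O)Nc1ccc(C(=O)/C=C/c2ccc(OC)cc2)cc1` gives 900 nM. Compound 1 and compound 2 differ in one place, (3-methoxyphenyl in place of 4-methoxyphenyl on a carbonyl carbon), and this brought a 2.1-fold higher number from compound 1 to compound 2 (0.33 log units; beyond the scatter). Compound 3 and compound 1 share the same atoms joined differently, but the difference between their two cores is not broken down here; their values lie within the usual scatter of each other.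

Compound 4 `C=C(Br)C(=O)Nc1ccc(C(=O)/C=C/c2cccc(OC)c2)cc1` is not yet measured. It stands to compound 3 as compound 2 stands to compound 1: 3-methoxyphenyl in place of 4-methoxyphenyl on a double-bonded chain carbon bound to a double-bonded chain carbon. The place differs, though: in the first pair the exchange sits on a carbonyl carbon whose other neighbour is a double-bonded chain carbon, in the second on a double-bonded chain carbon bound to a double-bonded chain carbon, so this is the same kind of change, not the same change.

On the strength of a 2.1-fold higher number from compound 1 to compound 2 (0.33 log units; beyond the scatter), a comparable step is expected for compound 4, namely a 2.1-fold higher number from compound 3 to compound 4 (0.32 log units; beyond the scatter) in this assay. Compound 4 is therefore estimated at 1900 nM, between 900 nM and 4000 nM.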

Compound 4, half-maximal inhibitory concentration: 1100 nM
The estimate for compound 4 lay 1.7-fold (0.24 log units) above the measured number; the measured number falls inside the stated range.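

In this assay, 3-methoxyphenyl in place of 4-methoxyphenyl on a double-bonded chain carbon bound to a double-bonded chain carbon brought a 1.2-fold higher number from compound 3 to compound 4 (0.09 log units; within the scatter), so on this core the exchange cannot be told apart from repeat scatter. Set beside the same kind of change on the core of compound 1, this step does not differ measurably from the earlier one: the same change on two cores in this assay, a 2.1-fold higher number (0.33 log units; beyond the scatter) from compound 1 to compound 2 and a 1.2-fold higher number (0.09 log units; within the scatter) from compound 3 to compound 4, 1.8-fold (0.24 log units) apart, within the scatter of two such steps

Among these compounds, the result is therefore compatible with the change carrying over from one core to the other, but it does not establish this, since only one of the two steps lies beyond the scatter and each core offers a single pair.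

The compounds shown leave open how either core would respond if the aryl group carried an amine or a carboxylic acid instead of methoxy. They also leave open whether the pattern would hold with a plain acryloyl group in place of the 2-bromoacryloyl group.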